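This account rests on a few compounds, and the source may have more. Where it says the series, first, only, none or still open, it means among the compounds named here.

Notes on the series.

Going by the values given here, in an assay on thoracic aorta for binding affinity to Endothelin-1 receptor (Rattus norvegicus) (a lower number here means a stronger inhibitor, a higher number a weaker inhibitor), compound 2, `CCNc1ccc(S(=O)(=O)Nc2onc(C)c2C)cc1`, gives 5000 nM, the higher of the two numbers measured so far. The nearest point of comparison is compound 1, `CC(=O)Nc1ccc2c(S(=O)(=O)Nc3onc(C)c3C)cccc2c1`, which in this assay gives 1300 nM; the gap between the two is beyond the usual scatter, so compound 2 is the weaker of the pair on the numbers at hand. Among the compounds with values here, no pair of measured compounds differs in a single place, so no measured step exists to calibrate the change that follows.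

Compound 3, `Cc1noc(NS(=O)(=O)c2ccc(N(C)C)cc2)c1C`, is obtained from compound 2 by the change (dimethylamino in place of ethylamino on an aromatic carbon). The two share every atom and differ only in how the aminic substituent is joined. Nothing measured in this series speaks to such a rearrangement, and the expectation therefore rests on the small size of the change alone: no step beyond the scatter is anticipated, and the expected step from compound 2 to compound 3 is no change at the digits printed from compound 2 to compound 3 (within the scatter). For compound 3 the estimate in this assay is 5000 nM, with a plausible range from 1700 nM to 15000 nM.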

Compound 3, half-maximal inhibitory concentration: 84000 nM
The estimate for compound 3 lay 17-fold (1.23 log units) below the measured number; the whole stated range lies below it.
By their numbers in this assay, from the lowest: compound 1; then compound 2; then compound 3.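

In this assay, the aromatic carbon para to a large group proves sensitive to how its substituent is joined: ethylamino and dimethylamino have the same heavy atoms, yet the exchange gives a 17-fold higher number from compound 2 to compound 3 (1.23 log units; beyond the scatter), a large step. What is counted as different between the two groups is that ethylamino has 1 hydrogen-bond donor and dimethylamino has 0 hydrogen-bond donors, while each has 1 hydrogen-bond acceptor, so a rearrangement that leaves the composition intact is not neutral at this place in this pair. Nothing available bears on the origin of the step, and this single pair cannot separate the loss of the donor from any other difference between the two groups.

Still open, going by these compounds, is how a plain amine, methylamino or a longer chain such as propylamino on the same carbon would stand against compound 2 and compound 3. Also open, on these data alone, is whether a step of this size would recur on the core of compound 1, with ethylamino and dimethylamino in place of its acetylamino group.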